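Methoxy for fluoro on the N-aryl ring of compound 3

The compounds below may be only part of what the source reports. "The series", "measured", "known", "first", "only" and "open" are said of these compounds alone.

Within the data shown here, compound 3 `Cn1ccc2c(Oc3ccc(NC(=O)c4cn(-c5ccc(F)cc5)c5ccccc5c4=O)cc3F)ccnc21` gives 1460 nM in a functional assay on A549 cells (Homo sapiens) for inhibition, read by MTT assay, with a stated time of 72 h (on this read-out lower numbers stand for stronger inhibition and higher numbers for weaker inhibition), the highest of the three numbers so far. Compound 1 `O=C(Nc1ccc(Oc2ccnc3[nH]ccc23)cc1)c1cn(-c2ccc(F)cc2)c2ccccc2c1=O` gives 390 nM and compound 2 `O=C(Nc1ccc(Oc2ccnc3[nH]ccc23)cc1)c1cn(-c2ccc(Br)cc2)c2ccccc2c1=O` gives 450 nM; compound 3 stands beyond the scatter from both of them.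

Compound 4 `COc1ccc(-n2cc(C(=O)Nc3ccc(Oc4ccnc5c4ccn5C)c(F)c3)c(=O)c3ccccc32)cc1` differs from compound 3 in one place: methoxy in place of fluoro on an aromatic carbon, that is 4-fluorophenyl to 4-methoxyphenyl. Among the measured compounds shown here, the only measured step at this position of the shared core is a 1.2-fold higher number from compound 1 to compound 2 (0.06 log units; within the scatter), and that exchange of one halogen for another left the number within the scatter. For the measured compounds named here, no measured pair covers methoxy at this position, so the expectation rests on that single step alone. The step from compound 3 to compound 4 is therefore expected to stay within the scatter, as a 1.0-fold lower number from compound 3 to compound 4 (0.02 log units; within the scatter). For compound 4 the estimated value in this assay is 1400 nM, with a range from 600 nM to 3500 nM.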

Compound 4, half-maximal inhibitory concentration: 3210 nM
For compound 4 the middle estimate is 2.3-fold (0.36 log units) below the measured one, and the stated range covers the measured number.
By their numbers in this assay, from the lowest: compounds 1 and 2 (each within the scatter of the next); then compound 3; then compound 4.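

In this assay, among these compounds, methoxy in place of fluoro gives a 2.2-fold higher number from compound 3 to compound 4 (0.34 log units; beyond the scatter) and is the first change at this position, para to a large group, to move the number beyond the scatter. The change is modest and goes towards weaker inhibition, whereas the halogen exchange gave only a 1.2-fold higher number from compound 1 to compound 2 (0.06 log units; within the scatter) and stayed within the scatter, so the position is not indifferent to what it carries. No measurement at hand accounts for the shift from 4-fluorophenyl to 4-methoxyphenyl.

From the compounds shown here alone, the two steps stand on different cores, so whether methoxy would shift the number on the core of compound 1 remains open. Also open, going by these compounds, is how an amine, a carboxylic acid or a longer alkoxy chain at this position would read.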